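The source may report more compounds than this note shows. Statements on the series, on what has been measured and on what is new or still open speak of the compounds shown alone.

In a functional assay on DU-145 cells (Homo sapiens) for cytotoxicity, read by MTT assay, with a stated time of 48 h (on this read-out lower numbers stand for stronger inhibition and higher numbers for weaker inhibition), compound 1 (`CC(C)=CCC/C(C)=C/CC/C(C)=C/CC[C@@H]1[C@@]2(C)CC/C(=N\OCc3cn(-c4ccc(Cl)cc4)nn3)C(C)(C)[C@@H]2CC[C@@]1(C)O`) gives 16200 nM and compound 2 (`CC(C)=CCC/C(C)=C/CC/C(C)=C/CC[C@@H]1[C@@]2(C)CC/C(=N\OCc3cn(-c4cccc(C(F)(F)F)c4)nn3)C(C)(C)[C@@H]2CC[C@@]1(C)O`) gives 11800 nM within the scatter of each other. Compound 3 (`CC(C)=CCC/C(C)=C/CC/C(C)=C/CC[C@@H]1[C@@]2(C)CC/C(=N\OCc3cn(-c4c(Cl)cc([N+](=O)[O-])cc4Cl)nn3)C(C)(C)[C@@H]2CC[C@@]1(C)O`) differs from compound 1 by 2,6-dichloro-4-nitrophenyl in place of 4-chlorophenyl on an aromatic nitrogen on the same aromatic nitrogen. Among the compounds with values here, the one measured step that bears on this is a 1.4-fold lower number from compound 1 to compound 2 (0.14 log units; within the scatter) and it also changes only the group on that nitrogen. Within the data shown here, the 2,6-dichloro-4-nitrophenyl group has no measured precedent here, so confidence is limited. No step beyond the scatter is expected in this assay and the estimated step is a 1.4-fold lower number from compound 1 to compound 3 (0.13 log units; within the scatter) on this basis. Compound 3 is estimated at 12000 nM with an expected range of 5000 nM to 28000 nM for now.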

Compound 3, half-maximal inhibitory concentration: 16400 nM
For compound 3 the middle estimate is 1.4-fold (0.14 log units) below the measured one; low and high end bracket the measured number.
By their numbers in this assay, from the lowest: compounds 2, 1 and 3 (each within the scatter of the next).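

In this assay, 2,6-dichloro-4-nitrophenyl on the aromatic nitrogen gives a 1.0-fold higher number from compound 1 to compound 3 (0.01 log units; within the scatter) and a 1.4-fold higher number from compound 2 to compound 3 (0.14 log units; within the scatter). The three aryl groups at this position therefore all lie within the scatter of each other, and this now includes a group of 11 heavy atoms with 2 hydrogen-bond acceptors. No supporting data explain this outcome.

Still open, going by these compounds, is whether an amine or a carboxylic acid on the phenyl ring would give a step beyond the scatter. The same question applies to a longer chain in place of that ring.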